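Methoxy for Chloro: an Expected Cytotoxicity Reading

A few compounds are considered here, and "the series" means these few. Any claim that something is new, unique, unknown or untested is made for them only; others in the source may bear on it.

In an ADME assay on HEK-293T cells (Homo sapiens) for cytotoxicity, read by MTT assay, with a stated time of 72 h (a higher number here means a weaker inhibitor, a lower number a stronger inhibitor), compound 1 `O=C(Nc1nc2ccc(F)cc2s1)c1cn(-c2ccccc2)nc1-c1ccccc1` gives 17600 nM.
In this assay compound 2 `O=C(Nc1nc2ccc(F)cc2s1)c1cn(-c2ccccc2)nc1-c1ccc(Cl)cc1` gives > 50000 nM, which is a limit of the assay and not a number.

For the measured compounds named here, compound 2 thus stands at the limit of > 50000 nM in this assay, at which 1 of the 2 values shown sits; of the two measured compounds it is the one whose value is known only as a limit, and the step of an at least 2.8-fold higher number from compound 1 to compound 2 (0.45 log units; beyond the scatter) records how it differs from compound 1. Compound 3 `COc1ccc(-c2nn(-c3ccccc3)cc2C(=O)Nc2nc3ccc(F)cc3s2)cc1` is not yet measured. It differs from compound 2 by methoxy in place of chloro on an aromatic carbon. Going by the values given here, no measured step covers a methoxy group; the only step in hand, an at least 2.8-fold higher number from compound 1 to compound 2 (0.45 log units; beyond the scatter), concerns hydrogen to chloro and bears on this change only indirectly, through the group that leaves. Compound 2 sits at a limit, and the question for compound 3 is then whether it returns to a measurable number at all. On these grounds a number near the limit is expected for compound 3, and the step of an at least 1.3-fold lower number from compound 2 to compound 3 (0.11 log units; that floor lies within the scatter) is expected to lie within the scatter or slightly in either direction. Compound 3 is estimated at 38000 nM, with a range from 12000 nM to 120000 nM.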

Compound 3, half-maximal inhibitory concentration: 15400 nM
For compound 3 the middle estimate is 2.5-fold (0.39 log units) above the measured one, and the stated range covers the measured number.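

In this assay, replacing chloro with methoxy at this position, para to a large group, returns the series to a measurable number, with an at least 3.2-fold lower number from compound 2 to compound 3 (0.51 log units; beyond the scatter). Compared with the unsubstituted phenyl, methoxy gives a 1.1-fold lower number from compound 1 to compound 3 (0.06 log units; within the scatter), so a group at this position does not in itself separate a compound from the hydrogen parent: among the three compounds, only the chloro group of compound 2 stands apart, while methoxy and hydrogen cannot be told apart in this assay. That separation has a lower bound only, and compound 2 is the one compound here whose reading is a limit of the assay and not a number: the limit of > 50000 nM in this assay, at which 1 of the 3 values shown sits.

On these data alone, how far compound 2 lies beyond its limit remains open, and so does the full size of each step that touches it. As far as these compounds go, it is also open whether the separation belongs to chloro alone or extends to other groups at this position, such as fluoro, methyl, an amine or a carboxylic acid, and whether the same exchange would read alike on a changed core.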